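Amide swap on the side-chain carbonyl of compound 3

The compounds below may be only part of what the source reports. "The series", "measured", "known", "first", "only" and "open" are said of these compounds alone.

Working notes on the series. Compound 1 `CCN1CCN(C(=O)C[C@H](Cc2ccc(Cl)cc2)C(=O)N2CCN(c3ccccc3N(CC3CC3)S(C)(=O)=O)CC2)CC1` returns in a functional assay with Melanocortin receptor 4 (Homo sapiens) as the target, read by cAMP accumulation (on this read-out lower numbers stand for an effect already at smaller amounts and higher numbers for an effect only at larger amounts of compound), only a limit, > 10000 nM. Compound 2 `CS(=O)(=O)N(CC1CC1)c1ccccc1N1CCN(C(=O)[C@H](CC(=O)N2CCN(CC3CC3)CC2)Cc2ccc(Cl)cc2)CC1` likewise returns a limit in this assay, > 10000 nM. The step that the two limits leave unreadable from compound 1 to compound 2 therefore cannot be read; both values sit at the limit of > 10000 nM in this assay, at which 2 of the 3 values shown sit. Within the data shown here, compound 3 `CCN(C(C)=O)C(C)c1ccccc1N1CCN(C(=O)[C@H](CC(=O)N2CCC2)Cc2ccc(Cl)cc2)CC1` is the one compound with a number in this assay, giving 340 nM.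

Compound 4 `CCN(C(C)=O)C(C)c1ccccc1N1CCN(C(=O)[C@H](CC(=O)NCc2ccccn2)Cc2ccc(Cl)cc2)CC1` differs from compound 3 in one place: ((pyridin-2-yl)methyl)amino in place of azetidin-1-yl on a carbonyl carbon. Among the measured compounds shown here, no measured step bears on this change; the single measured step, from compound 1 to compound 2, is unreadable and concerns a different position. The expectation for compound 4 therefore rests on compound 3 alone, with a wide range around it. The step of a 1.5-fold higher number from compound 3 to compound 4 (0.17 log units; within the scatter) is estimated to stay within the usual scatter. Compound 4 is expected to give about 500 nM in this assay, with a range from 120 nM to 2500 nM.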

Compound 4, half-maximal effective concentration: 37 nM
Beside the measured number, compound 4's estimate is 14-fold (1.13 log units) above it; measured number outside the range, below it.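

In this assay, among these compounds, ((pyridin-2-yl)methyl)amino in place of azetidin-1-yl on the carbonyl carbon gives a 9.2-fold lower number from compound 3 to compound 4 (0.96 log units; beyond the scatter), so this position responds to the group on the carbonyl in a way the earlier compounds could not show. The entering group brings a six-membered aromatic ring with 1 hetero atom and 1 hydrogen-bond donor, and these features change together in this single step, so none of them can be singled out. Nothing at hand accounts for the size of the step.

Still open, from the compounds shown here alone, is whether the ring nitrogen of the pyridine matters, which a benzylamino group in the same place would test. Also open, going by these compounds, are the roles of the amide hydrogen and the chain length, which a methylated amide nitrogen and a (2-(pyridin-2-yl)ethyl)amino group would address.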